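This account rests on a few compounds, and the source may have more. Where it says the series, first, only, none or still open, it means among the compounds named here.

Compound 1, `COc1cccc(-c2cnc(NC(=O)c3ccc(F)cc3)n2C)c1`: > 100000 nM
Compound 2, `COc1ccc(-c2cnc(NC(=O)c3ccno3)n2C)cc1`: > 100000 nM
Compound 3, `COc1ccccc1-c1cnc(NC(=O)c2ncc[nH]2)n1C`: > 50000 nM

All three compounds were tested in a toxicity assay on THP-1 cells (Homo sapiens) for inhibition; a higher number here means that more compound is tolerated, a lower number that less compound is tolerated. For compound 2 the figure > 100000 nM is a limit of the assay, not a measured number. Compound 1 likewise gives only a limit, > 100000 nM. Compound 3 gives a limit as well, > 50000 nM. Compound 2 thus stands where most of the values sit: the limit of > 100000 nM in this assay, at which 2 of the 3 values shown sit, while the remaining value sits at the limit of > 50000 nM in this assay, at which 1 of the 3 values shown sits.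

Compound 4, `COc1ccc(-c2cnc(NC(=O)c3ccccc3Br)n2C)cc1`, has not yet been measured in this assay. It differs from compound 2 in one place: 2-bromophenyl in place of 1,2-oxazol-5-yl on a carbonyl carbon. Within the data shown here, no step between two measured compounds is available, so the size of this change cannot be read from the data. Because every measured value sits at a limit (the limit of > 100000 nM in this assay, at which 2 of the 3 values shown sit, and (the limit of > 50000 nM in this assay, at which 1 of the 3 values shown sits)), the step of a number no higher from compound 2 to compound 4 (the limit leaves the size open) is expected to be none beyond the usual scatter. Compound 4 is therefore expected to give about 100000 nM in this assay, with a range from 50000 nM to 200000 nM, most likely reported again only as a limit.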

Compound 4, half-maximal cytotoxic concentration: > 100000 nM
Compound 4: a limit, no number; the forecaster's own chance of this, stated with the estimate: 75%; the middle value lies on the limit itself.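

Compound 2 and compound 4 both give only a limit in this assay, and the step between them cannot be read. The compounds shown leave open the concentration at which any of them harms these cells, and whether changing the group on the carbonyl carbon shifts it.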